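The source may hold more compounds than are shown below. What is called first, only, known or untested is meant among the compounds shown, and "the series" means these compounds.

Measured compounds:
Compound 1 `COC(=O)c1c[nH]c2cc(OC)c(Cl)cc2c1=O`: 37000 nM
Compound 2 `CCCCc1cc2c(=O)c(-c3ccccc3)c(C)[nH]c2cc1OCCOc1ccccc1`: 23000 nM

Going by the values given here, only two compounds have been measured so far, and they differ in more than one place. In an ADME assay on J774 cells (Mus musculus) for antiproliferative activity, with a stated time of 72 h (on this read-out lower numbers stand for an effect already at smaller amounts and higher numbers for an effect only at larger amounts of compound), compound 2 gives 23000 nM and compound 1 gives 37000 nM. These two values lie within the usual scatter of each other, so neither can be placed ahead of the other.

The next compound, compound 3 `CCCCc1cc2c(=O)c(-c3ccc(OC(F)(F)F)cc3)c(C)[nH]c2cc1OCCOc1ccccc1`, keeps the structure of compound 2 except at a single site. Trifluoromethoxy stands in place of hydrogen on an aromatic carbon, para to a large group, turning phenyl into 4-(trifluoromethoxy)phenyl (trifluoromethoxy in place of hydrogen on an aromatic carbon).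

Among the compounds with values here, no measured pair in this set differs in one place only, so the data give no direct guide to the size of such a change. The expectation in this assay is therefore no step beyond the scatter, in either direction, starting from compound 2 at 23000 nM. The expected change is a 1.2-fold lower number from compound 2 to compound 3 (0.06 log units; within the scatter). For compound 3 the estimated value is 20000 nM, with an expected range from 7000 nM to 50000 nM.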

Compound 3, half-maximal effective concentration: 20000 nM
Estimate against measurement, compound 3: no gap at the digits printed; measured number inside the range.
By their numbers in this assay, from the lowest: compounds 3, 2 and 1 (each within the scatter of the next).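

In this assay, going by these compounds alone, the step from hydrogen to trifluoromethoxy gives the first reading of a change at a single site, and it is a 1.2-fold lower number from compound 2 to compound 3 (0.06 log units; within the scatter). At this aromatic carbon, para to a large group, the phenyl of compound 2 can thus become the 4-(trifluoromethoxy)phenyl of compound 3 without the number moving beyond the usual scatter, something the comparison of compound 1 with compound 2, which differ in more than one place, could not show. The compounds shown offer no independent measurement that would explain this outcome.

On these data alone, because this is one substituent at one site, it remains open whether an amine, a carboxylic acid or a longer chain on the same carbon would likewise leave the number within the scatter or would produce a clear step in either direction. The compounds shown also leave open how the number responds to changes elsewhere on the shared core, and whether any single change in this series can move it beyond the scatter at all.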